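The compounds below may be only part of what the source reports. "The series", "measured", "known", "first", "only" and "open" are said of these compounds alone.

Working notes on a small set of trifluoromethyl hydroxy amides tested in an assay on a protein complex (Cavia porcellus) with sulfonylurea receptors; K-ATP channels (Homo sapiens) as the target; on this read-out lower numbers stand for stronger inhibition and higher numbers for weaker inhibition. Compound 1 `CCC(C)N(C(C)CC)S(=O)(=O)c1ccc(NC(=O)C(C)(O)C(F)(F)F)cc1` carries a bis(sec-butyl)amino group on its sulfonyl sulfur. In this assay compound 1 returns only a limit, > 30000 nM, and no number. Among the measured compounds shown here, compound 2 `CC(O)(C(=O)Nc1ccc(-c2nn[nH]n2)cc1)C(F)(F)F` is the other compound measured so far. In this assay compound 2 likewise returns only a limit, > 30000 nM. Where compound 1 stands is therefore simple: both measured values sit at the same limit, (the limit of > 30000 nM in this assay, at which 2 of the 2 values shown sit), so neither compound can be ranked relative to the other, and no step between measured compounds exists in this assay.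

Compound 3 `CC(O)(C(=O)Nc1ccc(S(=O)(=O)N2CCCC2)cc1)C(F)(F)F` is not yet measured. It differs from compound 1 in one place: pyrrolidin-1-yl in place of bis(sec-butyl)amino on a sulfonyl sulfur. The smaller group enters where the larger one leaves, on the sulfonyl sulfur whose other neighbour is an aromatic carbon. With both measured values at the limit, no direction for this change can be read from the series, and any step would be expected to stay within the scatter. The expected step is a number no higher from compound 1 to compound 3 (the limit leaves the size open), none beyond the scatter. Compound 3 is estimated at 30000 nM, within a range from 8000 nM to 100000 nM, with a high chance that this assay again reports only a limit.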

Compound 3, half-maximal inhibitory concentration: 880 nM
Estimate against measurement, compound 3: 34-fold (1.53 log units) above; measured number outside the range, below it.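

In this assay compound 3 is the only compound shown with a number rather than a limit, so the sulfonyl sulfur whose other neighbour is an aromatic carbon is now a place where the read-out responds to the group it carries. Pyrrolidin-1-yl in place of bis(sec-butyl)amino gives an at least 34-fold lower number from compound 1 to compound 3 (1.53 log units; beyond the scatter), a large step beyond the scatter, as a ring enters and the group loses heavy atoms. On an aromatic carbon, (pyrrolidin-1-yl)sulfonyl in place of 2H-tetrazol-5-yl gives an at least 34-fold lower number from compound 2 to compound 3 (1.53 log units; beyond the scatter), so compound 3 stands apart from both of the other compounds shown, along two different single changes.

Compound 1 and compound 2 each stand at a limit, so both steps are bounds and their true size stays open: the limit of > 30000 nM in this assay, at which 2 of the 3 values shown sit.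

On these data alone, a dimethylamino or a piperidin-1-yl group on the same sulfonyl sulfur would show whether the ring or the smaller count of heavy atoms goes with the step, and how the trifluoromethyl hydroxy amide end contributes also stays open.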